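The source may report more compounds than this note shows. Statements on the series, on what has been measured and on what is new or still open speak of the compounds shown alone.

Of the compounds shown here, two have been measured in a functional assay (Homo sapiens) for inhibition; on this read-out higher numbers stand for weaker inhibition and lower numbers for stronger inhibition. Compound 1 `COc1cc(/C=C/C(=O)c2cccc(O)c2)cc(OC)c1` gives 3200 nM in this assay. Compound 2 `COc1ccc(/C=C/C(=O)c2ccccc2Br)c(OC)c1` gives 35000 nM in this assay, the higher of the two numbers; the gap to compound 1 lies beyond the usual scatter, so compound 2 is the weaker inhibitor of the two measured. Among the compounds with values here, the two structures differ in more than one place, so no single step between them can be read off.

The next compound, compound 3 `COc1ccc(/C=C/C(=O)c2ccccc2O)c(OC)c1`, keeps the core of compound 2 and changes one thing: hydroxy in place of bromo on an aromatic carbon. Within the data shown here, no measured pair shows this change on its own, so its size here has no direct precedent. Compound 1, the lower of the two numbers, also carries a hydroxy, but it differs from compound 3 elsewhere as well and is no clean guide. For compound 3 a moderate step toward a lower number is expected, a 2.9-fold lower number from compound 2 to compound 3 (0.46 log units; beyond the scatter), with wide uncertainty. Compound 3 is estimated at 12000 nM in this assay, within a range of 3500 nM to 40000 nM.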

Compound 3, half-maximal inhibitory concentration: 144000 nM
For compound 3 the middle estimate is 12-fold (1.08 log units) below the measured one; the whole stated range lies below it.
By their numbers in this assay, from the lowest: compound 1; then compound 2; then compound 3.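

In this assay, hydroxy in place of bromo on an aromatic carbon, ortho to a large group, gives a 4.1-fold higher number from compound 2 to compound 3 (0.61 log units; beyond the scatter), so on this core the change runs toward weaker inhibition, and bromo is the better of the two groups at this position. Within the data shown here, this is the first step that isolates a single place, and it gives the position a direct reading that the earlier pair of compounds, differing in more than one place, could not supply. Nothing at hand bears on why the number rises with this change.

From the compounds shown here alone, whether an amine, a chloro or a carboxylic acid in the same place would give a number nearer to that of compound 2 or that of compound 3 remains open. Also open, going by these compounds, is whether the swap from 2-bromophenyl to 2-hydroxyphenyl would run the same way on the core of compound 1, since this single step speaks for one core only.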